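The source may hold more compounds than are shown below. What is called first, only, known or untested is meant among the compounds shown, and "the series" means these compounds.

In an ADME assay on cells (Hepatocyte, Mus musculus) for metabolic stability, read by LC-MS, tested at 3 uM (a lower number here means that the compound disappears faster, a higher number that the compound lasts longer), compound 2 `COc1ccnc(-c2nc(O)c(O)c(C(=O)N[C@H](C)C3CCCCC3)n2)c1` gives 1.9 h and compound 1 `C[C@@H](NC(=O)c1nc(-c2cc(C(F)(F)F)ccn2)nc(O)c1O)C1CCCCC1` gives 2.4 h, so the two values lie within the scatter of each other. Compound 3 `C[C@@H](NC(=O)c1nc(-c2cc(Cl)ccn2)nc(O)c1O)C1CCCCC1` carries a new change relative to compound 2: chloro in place of methoxy on an aromatic carbon. For the measured compounds named here, the one measured step at this place, methoxy in place of trifluoromethyl, is a 1.3-fold lower number from compound 1 to compound 2 (0.10 log units; within the scatter), and it stays within the scatter. Going by the values given here, no chloro compound has been measured yet, so only a small expected change, a 1.2-fold higher number from compound 2 to compound 3 (0.06 log units; within the scatter), is estimated, with no real shift beyond the scatter. For compound 3 the estimated half-life is 2.2 h, with an expected range of 1.3 h to 3.6 h.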

Compound 3, half-life: 1.7 h
Compound 3: middle estimate off by 1.3-fold (0.11 log units), on the high side; the range from low to high includes it.
By their numbers in this assay, from the lowest: compounds 3, 2 and 1 (each within the scatter of the next).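

In this assay, chloro at this place gives a 1.1-fold lower number from compound 2 to compound 3 (0.05 log units; within the scatter) and a 1.4-fold lower number from compound 1 to compound 3 (0.15 log units; within the scatter). Methoxy, trifluoromethyl and chloro therefore cannot be told apart here, so this third group extends the flat picture that a single step could only suggest. Nothing measured here bears on the reason for this result. From the compounds shown here alone, it remains open whether a different kind of group at this place, such as an amine, a carboxylic acid or a longer chain, would move the half-life beyond the scatter. The compounds shown also differ only at this place, so the effect of changes elsewhere in the molecule remains unknown.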